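The source may hold more compounds than are shown below. What is called first, only, known or untested is meant among the compounds shown, and "the series" means these compounds.

Measured so far in a functional assay on ileum for inhibition of histamine H1 receptor (Cavia porcellus); on this read-out lower numbers stand for stronger inhibition and higher numbers for weaker inhibition:
compound 1 `CCCCCCCn1c(N2CCN(C)CC2)nc2ccccc21` — 150 nM
compound 2 `CCCC(C)Cn1c(N2CCN(C)CC2)nc2ccccc21` — 500 nM
compound 3 `COCCn1c(N2CCN(C)CC2)nc2ccccc21` — 13 nM

Compound 3 stands lowest of the three numbers. The steps leading to it are a 12-fold lower number from compound 1 to compound 3 (1.06 log units; beyond the scatter) and a 38-fold lower number from compound 2 to compound 3 (1.59 log units; beyond the scatter); both lie beyond the scatter, so compound 3 is the strongest inhibitor among the measured set.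

Compound 4 `CCSCCn1c(N2CCN(C)CC2)nc2ccccc21` differs from compound 3 in one place: ethylsulfanyl in place of methoxy on a saturated chain carbon, two bonds along the chain from an aromatic nitrogen. Among the compounds with values here, the step that bears most directly on this change is the one from compound 1 to compound 3, a 12-fold lower number from compound 1 to compound 3 (1.06 log units; beyond the scatter), in which a pentyl group left and methoxy entered at the same place on the chain; the two-heavy-atom methoxy group went with a large lowering of the number. The step from compound 1 to compound 2, a 3.3-fold higher number from compound 1 to compound 2 (0.52 log units; beyond the scatter), shows that a change within the chain can shift the number modestly. Compound 4 carries an ethylsulfanyl group of three heavy atoms where compound 3 carries methoxy, a group between the short methoxy and the longer alkyl chains in size. A modest rise in the number is therefore expected, with the step from compound 3 to compound 4 in this assay estimated at a 3.1-fold higher number from compound 3 to compound 4 (0.49 log units; beyond the scatter). Compound 4 is expected to give about 40 nM in this assay, within a range of 12 nM to 130 nM.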

Compound 4, half-maximal inhibitory concentration: 19 nM
For compound 4 the middle estimate is 2.1-fold (0.32 log units) above the measured one, within the range that was stated.
By their numbers in this assay, from the lowest: compounds 3 and 4 (each within the scatter of the next); then compound 1; then compound 2.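

In this assay, the exchange of methoxy for ethylsulfanyl on a saturated chain carbon, two bonds along the chain from an aromatic nitrogen, comes to a 1.5-fold higher number from compound 3 to compound 4 (0.16 log units; within the scatter) and so cannot be told apart from repeat measurement. The low number is therefore not tied to methoxy alone: the chain carrying ethylsulfanyl also stands clear of the all-carbon chains, with a 7.9-fold lower number from compound 1 to compound 4 (0.90 log units; beyond the scatter) and a 26-fold lower number from compound 2 to compound 4 (1.42 log units; beyond the scatter), the latter a large step and the former a modest one. Nothing on hand explains why the chain bearing sulfur and the chain bearing oxygen sit together in this way.

Methoxy and ethylsulfanyl differ in both the atom bound to the chain and the number of carbons, so ethoxy or methylsulfanyl at this place would be needed to tell which of the two matters, and that remains open. As far as these compounds go, it is also open whether numbers this low would hold with a hydroxyl, an amine or a carboxylic acid at the same place on the chain, or with a longer ether or thioether chain.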